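Benzamide series: removal of the benzyl methyl in compound 2

The source may hold more compounds than are shown below. What is called first, only, known or untested is meant among the compounds shown, and "the series" means these compounds.

Working notes on a small set of benzamides carrying a 2-aminophenyl amide, all run in a functional assay on CAL-27 cells (Homo sapiens) for cytotoxicity, read by MTT assay, with a stated time of 72 h; a lower number here means a stronger inhibitor, a higher number a weaker inhibitor. Compound 1 `Cc1cc(C)cc(C(=O)N(CC(=O)NCc2ccccc2)Cc2ccc(C(=O)Nc3cc(F)ccc3N)cc2)c1` gives 5720 nM. Compound 3 `Nc1ccccc1NC(=O)c1ccc(CN(CC(=O)NCc2ccccc2)C(=O)c2cccnc2)cc1` gives 11200 nM. Compound 2 `Cc1ccc(CNC(=O)CN(CCCCCC(=O)Nc2ccccc2N)C(=O)c2cc(C)cc(C)c2)cc1` gives 18200 nM, the highest number of the three; its gap to compound 3 lies within the scatter, so no order between these two is claimed, whereas its number sits beyond the scatter above that of compound 1.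

The next structure to be measured is compound 4 `Cc1cc(C)cc(C(=O)N(CCCCCC(=O)Nc2ccccc2N)CC(=O)NCc2ccccc2)c1`. It differs from compound 2 in one place: hydrogen in place of methyl on an aromatic carbon The same change, read one bond further out, is 4-methylbenzyl to benzyl on the glycinamide nitrogen.

Within the data shown here, no pair of measured compounds differs in only this place, so no step of this kind is on record. The unsubstituted benzyl is shared by compound 1 and compound 3, whose numbers are lower than that of compound 2, but those compounds also differ elsewhere, so their values give only weak guidance. The expectation for the step of a 1.3-fold lower number from compound 2 to compound 4 (0.11 log units; within the scatter) is a small change, if any, toward a lower number, not clearly beyond the scatter.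

Compound 4 is estimated at 14000 nM, expected between 5500 nM and 36000 nM.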

Compound 4, half-maximal inhibitory concentration: 13700 nM
Estimate against measurement, compound 4: 1.0-fold (0.01 log units) above, within the range that was stated.
By their numbers in this assay, from the lowest: compounds 1, 3, 4 and 2 (each within the scatter of the next, the first and the last beyond it).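

In this assay, among these compounds, the first single-place comparison at this position reads a 1.3-fold lower number from compound 2 to compound 4 (0.12 log units; within the scatter), so 4-methylbenzyl and benzyl on the glycinamide nitrogen cannot be placed in any order here. The earlier compounds shown here could not show this, since those with the unsubstituted benzyl also differ from compound 2 elsewhere; with the rest of compound 2 held fixed, taking away the methyl on the aromatic carbon para to a large group gives no change beyond the scatter. No measurement on record offers a reason for this result, and the step is read only as a size.

On these data alone, whether a chlorine, a methoxy group, an amine or a carboxylic acid on this same carbon would also stay within the scatter of compound 4 remains open, and a single step cannot say how far this position accepts change. Also open, as far as these compounds go, is whether a 4-methylbenzyl group would give a similarly small step when placed on the frameworks of compound 1 and compound 3 rather than that of compound 4.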